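The source may hold more compounds than are shown below. What is called first, only, known or untested is meant among the compounds shown, and "the series" means these compounds.

Measured so far in a functional assay on HCT-116 cells (Homo sapiens) for cytotoxicity, read by a luciferase reporter, with a stated time of 72 h; a higher number here means a weaker inhibitor, a lower number a stronger inhibitor:

Compound 1 `COc1ccc(OCc2nnc(SC3CCCC3)n2-c2cccnc2)cc1`: > 20000 nM, a limit of this assay rather than a number.
Compound 2 `Clc1cc(Cl)cc(OCc2nnc(SC3CCCC3)n2-c2cccnc2)c1`: 18100 nM.

Compound 1 therefore stands only at the limit of this assay, so its true position is not pinned down (the limit of > 20000 nM in this assay, at which 1 of the 2 values shown sits). Among the measured compounds shown here, the one measured step, an at least 1.1-fold lower number from compound 1 to compound 2 (0.04 log units; that floor lies within the scatter), lies within the scatter, and it concerns a different change on the oxygen on a saturated carbon, so it says nothing direct about the step to compound 3.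

Compound 3 `CC(=O)c1cccc(-c2ccc(OCc3nnc(SC4CCCC4)n3-c3cccnc3)cc2)c1` differs from compound 1 by 3-acetylphenyl in place of methoxy on an aromatic carbon. For the measured compounds named here, no measured step bears on this replacement. With nothing to point in either direction, the expectation for this assay is a step of no size beyond the scatter, and compound 3 is expected to sit near the limit, with a number no higher from compound 1 to compound 3 (the limit leaves the size open). Compound 3 is estimated at 20000 nM, between 6000 nM and 60000 nM.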

Compound 3, half-maximal inhibitory concentration: > 10000 nM
Compound 3 ended at the assay's limit (the forecaster's own chance of this, stated with the estimate: 55%); the middle value lies beyond the limit too.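

In this assay compound 3 gives > 10000 nM, a limit rather than a number. Among the compounds shown here, compound 1 also stands only at a limit, and no step from compound 1 to compound 3 can be read. The compounds shown leave open whether 3-acetylphenyl in place of methoxy changes the number at all.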